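Urea to fluorophenyl amide on a benzimidazole-type cytotoxicity screen

The source may report more compounds than this note shows. Statements on the series, on what has been measured and on what is new or still open speak of the compounds shown alone.

Measured compounds in an ADME assay on Vero cells (Chlorocebus sabaeus) for cytotoxicity, read by resazurin assay, with a stated time of 3 days; on this read-out higher numbers stand for weaker inhibition and lower numbers for stronger inhibition:
Compound 1 `CCCNC(=O)Nc1cc2nc(C3CCCCC3)[nH]c2cc1N(CC)CC` gives > 100 ug/mL, a limit of the assay.
Compound 2 `CCOCCOC(=O)Nc1cc2nc(C3CCCCC3)[nH]c2cc1N1CCCC1` gives > 100 ug/mL, also a limit of the assay.
Compound 3 `CCCOCC(=O)Nc1cc2nc(C3CCCCC3)[nH]c2cc1N(C)C` gives < 50 ug/mL, again a limit rather than a number.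

Compound 1 therefore stands at the upper limit of this assay, where two of the three values sit, as described by the limit of > 100 ug/mL in this assay, at which 2 of the 3 values shown sit. Going by the values given here, compound 3 sits at the other limit, described by the limit of < 50 ug/mL in this assay, at which 1 of the 3 values shown sits, so the three compounds together span only what the two limits allow and no step between them can be sized. No pair of these compounds differs in a single place, so no measured step is available to lean on.

Compound 4 `CCN(CC)c1cc2[nH]c(C3CCCCC3)nc2cc1NC(=O)c1ccc(F)cc1` is the next compound to be tested. Relative to compound 1 it carries 4-fluorophenyl in place of propylamino on a carbonyl carbon. With compound 1 known only as a limit, the size of any step cannot be anchored; the expectation is that the change from compound 1 to compound 4 stays within the scatter or moves modestly toward stronger inhibition, that is, the expected step is an at least 1.2-fold lower number from compound 1 to compound 4 (0.09 log units; that floor lies within the scatter). The estimate for compound 4 in this assay is 80 ug/mL, expected to fall between 30 ug/mL and 150 ug/mL.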

Compound 4, half-maximal inhibitory concentration: > 100 ug/mL
Compound 4: a limit, no number; the forecaster's own chance of this, stated with the estimate: 50%; middle value at least 1.2-fold (0.09 log units) away from the limit.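

In this assay compound 1 and compound 4 sit at the same limit of the assay, so no step between them can be read: the limit of > 100 ug/mL in this assay, at which 3 of the 4 values shown sit.

The compounds shown leave open how far either compound lies past that limit, and so whether 4-fluorophenyl in place of propylamino on a carbonyl carbon changes the read-out at all.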